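The source may report more compounds than this note shows. Statements on the series, on what has been measured and on what is new or still open speak of the compounds shown alone.

Working notes on the series. Three measured compounds share one core and differ only in the group on one aromatic carbon. Compound 1 `Cc1cc(-c2ccc(Cl)cc2)c(S(C)(=O)=O)cc1C(=O)N=C(N)N` gives 45 nM in a functional assay for inhibition of sodium/hydrogen exchanger (Oryctolagus cuniculus); a lower number here means a stronger inhibitor, a higher number a weaker inhibitor. Compound 2 `Cc1cc(-c2cc(Cl)cc(Cl)c2)c(S(C)(=O)=O)cc1C(=O)N=C(N)N` gives 130 nM in this assay, and the step of a 2.9-fold higher number from compound 1 to compound 2 (0.46 log units; beyond the scatter). Compound 3 `Cc1cc(O)c(S(C)(=O)=O)cc1C(=O)N=C(N)N` gives 220 nM in this assay; this is the highest of the three numbers, with the step of a 4.9-fold higher number from compound 1 to compound 3 (0.69 log units; beyond the scatter), whereas the step of a 1.7-fold higher number from compound 2 to compound 3 (0.23 log units; within the scatter).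

Compound 4 `CCOc1cc(C)c(C(=O)N=C(N)N)cc1S(C)(=O)=O` differs from compound 3 by ethyl in place of hydrogen on an oxygen on an aromatic ring. Among the compounds with values here, every measured step exchanges the whole group on that aromatic carbon, swapping one chlorinated phenyl for another or a phenyl for hydroxy; none alters the hydroxy itself, so no measured step bears directly on this change. The steps reaching compound 3 were modest, and the hydroxy sits at the end of the series on the numbers shown, so the change is expected to move the number in this assay by no more than a 1.1-fold lower number from compound 3 to compound 4 (0.04 log units; within the scatter), which is within the scatter and without a claimed direction. Compound 4 is therefore expected to give about 200 nM in this assay, with a range from 70 nM to 600 nM.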

Compound 4, half-maximal inhibitory concentration: 19 nM
Compound 4: middle estimate off by 11-fold (1.02 log units), on the high side; measured number below the stated range.
By their numbers in this assay, from the lowest: compound 4; then compound 1; then compounds 2 and 3 (each within the scatter of the next).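

In this assay, within the data shown here, the group on the oxygen turns out to matter in its own right: ethyl in place of hydrogen gives a 12-fold lower number from compound 3 to compound 4 (1.06 log units; beyond the scatter) and is the only step graded large, whereas the earlier compounds showed only exchanges of the whole group on that aromatic carbon. Ethoxy also improves on both chlorinated phenyl groups, with a 6.8-fold lower number from compound 2 to compound 4 (0.84 log units; beyond the scatter) and a 2.4-fold lower number from compound 1 to compound 4 (0.37 log units; beyond the scatter) in this comparison, which makes compound 4 the strongest inhibitor of the four and shows that a phenyl ring on this carbon is not needed for a low number, although compound 3, also without that ring, goes against any reading that its absence alone is enough. Nothing measured here accounts for the size of the hydroxy to ethoxy step, so it stands as an observation only.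

With ethyl the only group shown on this oxygen, the compounds leave open how the number responds to methyl, to a longer chain such as propyl or butyl, or to a branched chain such as isopropyl. They also leave open whether an amine on the same aromatic carbon would track ethoxy or hydroxy.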